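Bromine for Fluorine on a Cyanoacrylate Scaffold

A few compounds are considered here, and "the series" means these few. Any claim that something is new, unique, unknown or untested is made for them only; others in the source may bear on it.

Compound 1, `COc1ccc(/C=C(\C#N)C(=O)c2cc(OC)c(OC)c(OC)c2)cc1O[Si](C)(C)C(C)(C)C`: in an ADME assay on K562 cells (Homo sapiens) for cytotoxicity, read by MTT assay, with a stated time of 5 days (on this read-out higher numbers stand for weaker inhibition and lower numbers for stronger inhibition), compound 1 gives > 10000 nM, which is a limit of the assay rather than a number.
Compound 2, `COc1ccc(/C=C(\C#N)C(=O)c2cc(OC)c(OC)c(OC)c2)cc1F`: in this assay compound 2 gives > 10000 nM, again a limit of the assay and not a number.

Compound 2 therefore stands nowhere precise on the numbers shown: it sits at the limit, as does every value recorded here (the limit of > 10000 nM in this assay, at which 2 of the 2 values shown sit). Among the measured compounds shown here, the single measured step, a step that the two limits leave unreadable from compound 1 to compound 2, runs between two limits and so cannot be given a size or a direction.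

Compound 3, `COc1ccc(/C=C(\C#N)C(=O)c2cc(OC)c(OC)c(OC)c2)cc1Br`, differs from compound 2 by bromo in place of fluoro on an aromatic carbon. For the measured compounds named here, no measured step covers this change. The only step shown is unreadable, so it offers no expectation of a shift in either direction; all that the data show is that the shared core, carrying either of the groups tried so far, stays at the limit.

For compound 3 the value in this assay is expected to be 10000 nM, with a range from 2000 nM to 50000 nM. The step from compound 2 to compound 3 is thus estimated as a number no higher from compound 2 to compound 3 (the limit leaves the size open), most likely again a limit rather than a number.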

Compound 3, half-maximal inhibitory concentration: > 10000 nM
Compound 3 was reported as a limit (the forecaster's own chance of this, stated with the estimate: 65%); the middle value sits exactly at the limit.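

In this assay compound 3 gives > 10000 nM, which is a limit of the assay and not a number. No step among compound 1, compound 2 and compound 3 can therefore be read, in size or in direction: the limit of > 10000 nM in this assay, at which 3 of the 3 values shown sit.

The compounds shown leave open how strongly any of the three acts in this assay, and whether another group at this place would give a number.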